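Terminal amine step from compound 3 to compound 4

This account rests on a few compounds, and the source may have more. Where it says the series, first, only, none or still open, it means among the compounds named here.

Measured in a functional assay on HCT-116 cells (Homo sapiens) for antiproliferative activity, read by MTT assay, with a stated time of 48 h; a higher number here means a weaker inhibitor, a lower number a stronger inhibitor:
- compound 1 `Cc1c(C(=O)NCCS(C)(=O)=O)oc2ccc(N(Cc3ccc(Br)cc3)S(=O)(=O)c3ccc(Br)cc3)cc12`: > 40000 nM (a limit of the assay)
- compound 2 `Cc1c(C(=O)NCCNc2ccccc2)oc2ccc(N(Cc3ccc(Br)cc3)S(=O)(=O)c3ccc(Br)cc3)cc12`: > 40000 nM (a limit of the assay)
- compound 3 `CN(C)CCNC(=O)c1nc2cc(N(Cc3ccc(Br)cc3)S(=O)(=O)c3ccc(Br)cc3)ccc2o1`: 14300 nM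

Among the compounds with values here, compound 3 gives the only true number in this set, 14300 nM. Compound 1 and compound 2 both sit at the limit of > 40000 nM in this assay, at which 2 of the 3 values shown sit.

Compound 4 `CCN(CC)CCNC(=O)c1nc2cc(N(Cc3ccc(Br)cc3)S(=O)(=O)c3ccc(Br)cc3)ccc2o1` carries diethylamino in place of dimethylamino on a saturated chain carbon, two bonds along the chain from an amide-type nitrogen.

Within the data shown here, one measured step touches this same place, a step that the two limits leave unreadable from compound 1 to compound 2. Among the measured compounds shown here, it therefore sets no size for the change at hand, and no measured step speaks to a direction. The expectation rests on compound 3 at 14300 nM alone. The expected change in this assay is a 1.1-fold lower number from compound 3 to compound 4 (0.04 log units; within the scatter), with no step beyond the scatter anticipated in either direction. For compound 4 the estimate is 13000 nM, with an expected range of 6000 nM to 30000 nM.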

Compound 4, half-maximal inhibitory concentration: 14300 nM
Compound 4: the middle estimate sits 1.1-fold (0.04 log units) below what was measured; low and high end bracket the measured number.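

In this assay, within the data shown here, the exchange of dimethylamino for diethylamino gives no change at the digits printed from compound 3 to compound 4 (within the scatter) and is the first readable step at this place, on a saturated chain carbon, two bonds along the chain from an amide-type nitrogen. Going from 3 heavy atoms to 5 heavy atoms in this group therefore keeps the read-out within the scatter on this core. This rests on one pair and sets no trend beyond compound 3 and compound 4.

Open, going by these compounds, is whether a ring amine such as pyrrolidine or morpholine, a primary amine, a carboxylic acid or a longer chain at this place would shift the value beyond the scatter. The step between compound 1 and compound 2 cannot be read, as both stand at a limit of the assay: the limit of > 40000 nM in this assay, at which 2 of the 4 values shown sit.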